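Replacing the Nitrile in Compound 2: Expected Cytotoxicity

The source may hold more compounds than are shown below. What is called first, only, known or untested is meant among the compounds shown, and "the series" means these compounds.

compound 1, `COc1cccc2[nH]c(C(=O)N[C@@H](CC(C)C)C(=O)N[C@H](C=O)C[C@@H]3CCNC3=O)cc12`: > 200000 nM
compound 2, `COc1cccc2[nH]c(C(=O)N[C@@H](CC(C)C)C(=O)N[C@H](C#N)C[C@@H]3CCCNC3=O)cc12`: > 200000 nM

In a toxicity assay on Vero C1008 cells (Chlorocebus sabaeus) for cytotoxicity, read by CCK-8 assay (on this read-out higher numbers stand for lower toxicity in this test and lower numbers for higher toxicity in this test), compound 1 gives > 200000 nM, which is a limit of the assay and not a number. Compound 2 gives > 200000 nM in this assay, again a limit. The step that the two limits leave unreadable from compound 1 to compound 2 is therefore unreadable. For the measured compounds named here, compound 2 thus stands only at a limit, and so does the one other value shown (the limit of > 200000 nM in this assay, at which 2 of the 2 values shown sit).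

Compound 3, `COc1cccc2[nH]c(C(=O)N[C@@H](CC(C)C)C(=O)N[C@@H](C[C@@H]3CCCNC3=O)C(=O)CO)cc12`, differs from compound 2 by (hydroxymethyl)carbonyl in place of cyano on a saturated chain carbon bound to an amide-type nitrogen and a saturated chain carbon. Going by the values given here, no measured step bears on this change, since both measured values are limits and give no readable size in either direction. Compound 3 is expected to sit at the same limit, so the estimated step that the limit leaves unreadable from compound 2 to compound 3 is none beyond the scatter. Compound 3 is estimated at 300000 nM, with a range from 100000 nM to 1000000 nM.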

Compound 3, half-maximal cytotoxic concentration: > 200000 nM
Compound 3: no number, only a limit; the forecaster's own chance of this, stated with the estimate: 85%; the middle value does not contradict the limit.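

In this assay, for the compounds shown here, compound 3 gives > 200000 nM, again a limit of the assay and not a number, so no step between compound 2 and compound 3 can be read. The compounds shown leave open whether cyano and (hydroxymethyl)carbonyl differ at all in this assay.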